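A few compounds are considered here, and "the series" means these few. Any claim that something is new, unique, unknown or untested is made for them only; others in the source may bear on it.

Compound 3 `O=[N+]([O-])c1ccc(NC(=S)NCCNS(=O)(=O)c2ccc(-c3ccccc3OCc3cccc(O)c3)s2)cc1` is measured in an ADME assay on HEK-293T cells (Homo sapiens) for cytotoxicity, read by CCK-8 assay, with a stated time of 48 h (on this read-out higher numbers stand for weaker inhibition and lower numbers for stronger inhibition), where compound 3 gives > 20000 nM, which is a limit of the assay rather than a number. Compound 1 `O=C(NCCNS(=O)(=O)c1ccc(-c2ccccc2OCc2cccc(O)c2)s1)Nc1cc(Cl)cc(Cl)c1` gives > 20000 nM in this assay, again a limit and not a number. Between them stands one change, (a group of 11 heavy atoms (7 carbon, 1 nitrogen, 1 oxygen, 2 chlorine; one six-membered aromatic ring of carbon only) in place of a group of 12 heavy atoms (7 carbon, 2 nitrogen, 2 oxygen, 1 sulfur; one six-membered aromatic ring of carbon only), on an amine nitrogen), and the step that the two limits leave unreadable from compound 3 to compound 1 cannot be sized because of the limit of > 20000 nM in this assay, at which 2 of the 3 values shown sit. Compound 2 `CC(C)c1ccc(Oc2ccc(O)c(O)c2)c(-c2ccsc2S(=O)(=O)NCCNC(=S)Nc2ccc([N+](=O)[O-])cc2)c1` is the only one of the three with a number: in this assay compound 2 gives 16300 nM. How the core of compound 2 differs from the core of compound 3 is not broken down here.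

Compound 4 `CC(C)c1ccc(Oc2ccc(O)c(O)c2)c(-c2ccsc2S(=O)(=O)NCCNC(=O)Nc2cc(Cl)cc(Cl)c2)c1` has not yet been measured. It arises from compound 2 by a group of 11 heavy atoms (7 carbon, 1 nitrogen, 1 oxygen, 2 chlorine; one six-membered aromatic ring of carbon only) in place of a group of 12 heavy atoms (7 carbon, 2 nitrogen, 2 oxygen, 1 sulfur; one six-membered aromatic ring of carbon only), on an amine nitrogen, the same change that turns compound 3 into compound 1. For compound 4 the expected step is a 1.2-fold higher number from compound 2 to compound 4 (0.09 log units; within the scatter), resting on the step from compound 3 to compound 1 being left unreadable because of the limit of > 20000 nM in this assay, at which 2 of the 3 values shown sit, so that no direction can be taken from it. Compound 4 is therefore estimated at 20000 nM, with a range from 9000 nM to 45000 nM, and a fair chance that only a limit is reported.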

Compound 4, half-maximal inhibitory concentration: > 10000 nM
Compound 4 gave a limit, no number; the forecaster's own chance of this, stated with the estimate: 55%; the middle value is on the limit's open side.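

In this assay compound 4 gives > 10000 nM which is a limit of the assay and not a number. Among these compounds, no step from compound 2 to compound 4 can therefore be read: the limit of > 10000 nM in this assay, at which 1 of the 4 values shown sits. The compounds shown leave open whether (3,5-dichlorophenyl)carbamoyl on the amine nitrogen moves this read-out in either direction, on either core.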